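A Methoxyphenyl Ethyl Variant and Cell Tolerance

The source may report more compounds than this note shows. Statements on the series, on what has been measured and on what is new or still open speak of the compounds shown alone.

Compound 1, `CCc1ccc2[nH]c(=O)c(CN(Cc3ccc(O)cc3)Cc3ccc(C(C)(C)C)cc3)cc2c1`: only a limit, > 10000 nM
Compound 2, `CCc1ccc2[nH]c(=O)c(CN(Cc3ccc(C(C)(C)C)cc3)[C@H](CO)c3ccccc3)cc2c1`: only a limit, > 10000 nM
Compound 3, `CCc1ccc2[nH]c(=O)c(CN(Cc3ccc(C(C)(C)C)cc3)[C@H](C)c3ccc(F)cc3)cc2c1`: only a limit, > 5000 nM

All three measured compounds were tested in a toxicity assay on MDCK cells (Canis lupus familiaris) for cytotoxicity, read by crystal violet staining, with a stated time of 48 h (a higher number here means that more compound is tolerated, a lower number that less compound is tolerated), and none gave a number. Compound 3 stands at a limit, because two other values sit at the limit of > 10000 nM in this assay, at which 2 of the 3 values shown sit, and its own at the limit of > 5000 nM in this assay, at which 1 of the 3 values shown sits, so the three cannot be ordered against each other. The steps leading to compound 3 are therefore unreadable: a step that the two limits leave unreadable from compound 1 to compound 3 and a step that the two limits leave unreadable from compound 2 to compound 3.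

Compound 4, `CCc1ccc2[nH]c(=O)c(CN(Cc3ccc(C(C)(C)C)cc3)[C@@H](C)c3ccc(OC)cc3)cc2c1`, differs from compound 3 in one place: 1-(4-methoxyphenyl)ethyl in place of 1-(4-fluorophenyl)ethyl on an amine nitrogen. Going by the values given here, no measured step gives a readable size for any change of this kind, so no direction beyond the scatter can be expected in this assay. The step from compound 3 to compound 4 is estimated as a step that the limit leaves unreadable from compound 3 to compound 4. Compound 4 is expected to give about 15000 nM, within a range from 5000 nM to 50000 nM, most likely again reported as a limit.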

Compound 4, half-maximal cytotoxic concentration: > 5000 nM
Compound 4: no number, only a limit (the forecaster's own chance of this, stated with the estimate: 85%); the middle value does not contradict the limit.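

Compound 4 also stands at a limit in this assay, so its steps from compound 1, compound 2 and compound 3 cannot be read: the limit of > 5000 nM in this assay, at which 2 of the 4 values shown sit.

The compounds shown leave open at what concentration any of them harms these cells, and whether changing the group on the amine nitrogen alters that tolerance at all.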